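Returning to a urea: an ethylamino acyl group on the shared core

A few compounds are considered here, and "the series" means these few. Any claim that something is new, unique, unknown or untested is made for them only; others in the source may bear on it.

Measured compounds:
Compound 1 `Cc1cn([C@@H]2O[C@@H]3COC(=O)[C@]3(OS(C)(=O)=O)[C@H]2O)c(=O)[nH]c1=O`: in a functional assay on HEL cells (Homo sapiens) for cytotoxicity, read by microscopy (a higher number here means that more compound is tolerated, a lower number that less compound is tolerated), compound 1 reaches only a limit of the assay, >= 400000 nM.
Compound 2 `CCOC(=O)CNC(=O)NC1=CS(=O)(=O)O[C@@]12[C@@H](CO[Si](C)(C)C(C)(C)C)O[C@@H](n1cc(C)c(=O)n(C)c1=O)[C@@H]2O[Si](C)(C)C(C)(C)C`: in this assay compound 2 gives 16000 nM.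
Compound 3 `COC(=O)CC(=O)NC1=CS(=O)(=O)O[C@@]12[C@@H](CO[Si](C)(C)C(C)(C)C)O[C@@H](n1cc(C)c(=O)n(C)c1=O)[C@@H]2O[Si](C)(C)C(C)(C)C`: in this assay compound 3 gives 400000 nM.

Compound 3 holds the highest number of the two numbers shown; its nearest measured neighbour is compound 2, and the one measured step between them, a 25-fold higher number from compound 2 to compound 3 (1.40 log units; beyond the scatter), is large. The step to compound 4 `CCNC(=O)NC1=CS(=O)(=O)O[C@@]12[C@@H](CO[Si](C)(C)C(C)(C)C)O[C@@H](n1cc(C)c(=O)n(C)c1=O)[C@@H]2O[Si](C)(C)C(C)(C)C` is ethylamino in place of (methoxycarbonyl)methyl on a carbonyl carbon. Among the compounds with values here, this change carries the acyl group back from the (methoxycarbonyl)methyl carbonyl of compound 3 to a carbamoyl of the same kind as in compound 2, so the step from compound 2 to compound 3 is the only measured step that bears on it, and it ran in the opposite direction. Reversing that movement, a lower number for compound 4 is expected, by roughly the size seen from compound 2 to compound 3, though the ethylamino group is not the ((ethoxycarbonyl)methyl)amino group of compound 2, so the match need not be exact. The expected step is a 10-fold lower number from compound 3 to compound 4 (1.00 log units; beyond the scatter). Compound 4 is therefore estimated at 40000 nM in this assay, with a range from 10000 nM to 400000 nM.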

Compound 4, minimum cytotoxic concentration: >= 3200 nM
Compound 4 was reported as a limit (the forecaster's own chance of this, stated with the estimate: 15%); the middle value is on the limit's open side.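

Compound 4 is reported in this assay only as a limit, >= 3200 nM, so its steps from compound 2 and from compound 3 cannot be read. The compounds shown leave open whether ethylamino in place of (methoxycarbonyl)methyl, or methyl in place of ethoxycarbonyl, changes the concentration tolerated at all, and in which direction.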